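Paw Edema Inhibition: A Methyl Added to Compound 1

This account rests on a few compounds, and the source may have more. Where it says the series, first, only, none or still open, it means among the compounds named here.

Measured compounds:
- compound 1, `O=c1c2ccccc2nc(CO[N+](=O)[O-])n1NS(=O)(=O)c1ccccc1`: 11.6%
- compound 2, `Cc1nc2ccccc2c(=O)n1NC(=S)Nc1ccccc1`: 42.9%
- compound 3, `Cc1nc2ccccc2c(=O)n1NC(=O)NC(C)(C)C`: 29.8%

In a functional assay on the whole organism (strain Sprague-Dawley) for inhibition, with Rattus norvegicus as the target, read by paw edema, with stated times of 30 min and 2 h, at a dose of 80 mg/kg by the oral route (on this read-out higher numbers stand for more inhibition at the one dose given (going by the name of the read-out) and lower numbers for less inhibition), compound 1 gives 11.6%, the lowest of the three numbers, and both other compounds stand beyond the scatter above it. Compound 4, `Cc1ccc(S(=O)(=O)Nn2c(CO[N+](=O)[O-])nc3ccccc3c2=O)cc1`, has not yet been measured. It differs from compound 1 in one place: methyl in place of hydrogen on an aromatic carbon. The change is small, a single carbon joining the ring that carries the sulfonyl group. Within the data shown here, no measured pair shows the effect of this change, so only a small step is expected, if any, and within the scatter. The expected step of a number 3.4 percentage points higher from compound 1 to compound 4 (within the scatter) is therefore close to none. Compound 4 is estimated to give 15%, with a likely range from 3% to 30%.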

Compound 4, a percentage reported as inhibition, in the whole organism at one dose (the size of the read-out at that dose, not a potency): 15.7%
Beside the measured number, compound 4's estimate is 0.7 percentage points below it, within the range that was stated.
By their numbers in this assay, from the lowest: compounds 1 and 4 (each within the scatter of the next); then compound 3; then compound 2.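

In this assay, among these compounds, the change from phenyl to 4-methylphenyl gives a number 4.1 percentage points higher from compound 1 to compound 4 (within the scatter) and so provides the first reading for this position. Adding methyl on this aromatic carbon leaves compound 1 and compound 4 indistinguishable on this read-out, at this one dose. Nothing measured here explains why the two read alike.

The compounds shown do not reveal whether an amine or a carboxylic acid at this place would read differently. They also leave open whether an ethyl group or a longer chain would stay within the scatter.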